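The source may report more compounds than this note shows. Statements on the series, on what has been measured and on what is new or still open speak of the compounds shown alone.

Compound 2 `N#Cc1cccc(C(=O)Nc2ncc(C(Oc3ccc4cc(Br)ccc4c3)c3ccc(Cl)cc3)s2)c1` is the anchor of this series. In an ADME assay on HepG2 2.2.15 cells (Homo sapiens) for cytotoxicity (a lower number here means that less compound is tolerated, a higher number that more compound is tolerated), compound 2 gives > 50000 nM; this is a limit of the assay and not a number. The only other entry, compound 1 `O=C(Nc1ncc(C(Oc2ccc3cc(Br)ccc3c2)c2ccc(Cl)cc2)s1)c1cc(F)c(F)cc1F`, carries no number in this assay either, being recorded as "not toxic" (no number reported). Both records thus point the same way, as the limit of > 50000 nM in this assay, at which 1 of the 2 values shown sits, shows for the limited one. Going by the values given here, no step between measured compounds can be drawn from two such entries.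

Compound 3 `O=S(=O)(Nc1ncc(C(Oc2ccc3cc(Br)ccc3c2)c2ccc(Cl)cc2)s1)c1ccc(Cl)nc1` differs from compound 2 by (6-chloropyridin-3-yl)sulfonyl in place of (3-cyanophenyl)carbonyl on a nitrogen on an aromatic ring. With nothing measured on either side of the change, the expected step from compound 2 to compound 3 in this assay is a number no higher from compound 2 to compound 3 (the limit leaves the size open), that is, none beyond the scatter. Compound 3 is therefore estimated at 50000 nM, within 20000 nM to 100000 nM, most likely again reported only as a limit.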

Compound 3, half-maximal cytotoxic concentration: "not toxic" (no number reported)
For compound 3 the study gives words and no number, so the estimate cannot be set against anything.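

No step can be read from compound 2 to compound 3 in this assay, since compound 3 gives "not toxic" (no number reported). Compound 2 gives > 50000 nM, a limit of the assay and not a number. The compounds shown leave open at what concentration either becomes cytotoxic, and whether (6-chloropyridin-3-yl)sulfonyl in place of (3-cyanophenyl)carbonyl changes that concentration.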